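The source may hold more compounds than are shown below. What is called first, only, known or untested is meant among the compounds shown, and "the series" means these compounds.

In a functional assay on IGROV-1 cells (Homo sapiens) for inhibition, read by sulforhodamine B assay, with a stated time of 48 h (a lower number here means that less compound is tolerated, a higher number that more compound is tolerated), compound 1 `Nc1cc(N)c2nc(-c3ccccc3)c(NCc3ccc(F)cc3)nc2c1` gives only a limit of the assay, < 100000 nM. Compound 2 `Nc1cc(N)c2nc(-c3ccccc3)c(Sc3ccc(Cl)c(Cl)c3)nc2c1` likewise gives only a limit of the assay in this assay, < 100000 nM. Between these two compounds the measurements show a step that the two limits leave unreadable from compound 1 to compound 2, so where compound 2 stands is known only as a limit, and the limit of < 100000 nM in this assay, at which 2 of the 2 values shown sit, is all that the two values tell. Compound 3 `Nc1cc(N)c2nc(-c3ccccc3)c(Sc3ccc(F)cc3)nc2c1` differs from compound 2 in one place: 4-fluorophenyl in place of 3,4-dichlorophenyl on a sulfur. Going by the values given here, no measured step changes the group on this sulfur, so nothing measured bears directly on this change, and the single known step is unreadable. The estimate therefore means a step that the limit leaves unreadable from compound 2 to compound 3, with no direction beyond the scatter supported by the data. Compound 3 is estimated at 30000 nM in this assay, within a range from 3000 nM to 100000 nM, and a limit rather than a number is again quite possible.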

Compound 3, concentration lethal to 50% of the cells: < 100000 nM
Compound 3 ended at the assay's limit; the forecaster's own chance of this, stated with the estimate: 55%; the middle value does not contradict the limit.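

Compound 3 gives only a limit of the assay, < 100000 nM. The steps from compound 1 and compound 2 to compound 3 cannot be read, because all three values are limits: the limit of < 100000 nM in this assay, at which 3 of the 3 values shown sit.

On these data alone, how far apart compound 1, compound 2 and compound 3 truly lie in this assay, and whether changing the group on the sulfur matters at all, stays open.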